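From Methoxy to Benzyloxycarbonyl on a Shared Core

The compounds below may be only part of what the source reports. "The series", "measured", "known", "first", "only" and "open" are said of these compounds alone.

Measured in a functional assay on A549 cells (Homo sapiens) for antiproliferative activity, read by MTT assay, with a stated time of 48 h; on this read-out higher numbers stand for weaker inhibition and lower numbers for stronger inhibition:
Compound 1 `O=C(OCc1ccccc1)c1ccc2[nH]c(-c3cn(-c4ccccc4)nc3-c3ccccc3)nc2c1`: 19300 nM
Compound 2 `Fc1ccc2[nH]c(-c3cn(-c4ccccc4)nc3-c3ccc(Cl)cc3)nc2c1`: 4610 nM
Compound 3 `COc1ccc2[nH]c(-c3cn(-c4ccccc4)nc3-c3ccc(Cl)cc3)nc2c1`: 2420 nM

Compound 3 has the lowest number of the three, but its lead over compound 2 is not a real one, since a 1.9-fold lower number from compound 2 to compound 3 (0.28 log units; within the scatter) lies within the scatter. Compound 1 stands clearly above compound 3 on the values shown.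

Compound 4 `O=C(OCc1ccccc1)c1ccc2[nH]c(-c3cn(-c4ccccc4)nc3-c3ccc(Cl)cc3)nc2c1` has benzyloxycarbonyl in place of the methoxy of compound 3 on an aromatic carbon: benzyloxycarbonyl in place of methoxy on an aromatic carbon. For the measured compounds named here, the only measured step at this carbon is a 1.9-fold lower number from compound 2 to compound 3 (0.28 log units; within the scatter), which stays within the scatter and does not involve benzyloxycarbonyl. The closest evidence is compound 1, which carries the same benzyloxycarbonyl group on a different core and gives 19300 nM. This points to a rise, though the size is uncertain. In this assay a higher number is therefore expected, an estimated 3.3-fold higher number from compound 3 to compound 4 (0.52 log units; beyond the scatter). Compound 4 is expected at 8000 nM, with an estimated range of 3000 nM to 20000 nM.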

Compound 4, half-maximal inhibitory concentration: 7730 nM
Estimate against measurement, compound 4: 1.0-fold (0.01 log units) above, and the stated range covers the measured number.
By their numbers in this assay, from the lowest: compounds 3, 2 and 4 (each within the scatter of the next, the first and the last beyond it); then compound 1.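

In this assay, for the compounds shown here, benzyloxycarbonyl is the first group at this aromatic carbon to stand apart from methoxy, with a 3.2-fold higher number from compound 3 to compound 4 (0.50 log units; beyond the scatter), yet it does not stand apart from fluoro, with a 1.7-fold higher number from compound 2 to compound 4 (0.22 log units; within the scatter). Going by these compounds alone, with benzyloxycarbonyl held in place, the pair also gives the first measured step at a second site, chloro in place of hydrogen on an aromatic carbon, with a 2.5-fold lower number from compound 1 to compound 4 (0.40 log units; beyond the scatter). No measurement shown here accounts for either change.

As far as these compounds go, it remains open where a carboxylic acid or a primary amide at this carbon would fall relative to methoxy and benzyloxycarbonyl. From the compounds shown here alone, it is also open whether the step for chloro in place of hydrogen carries over to the compounds bearing methoxy or fluoro.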